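Cytotoxicity notes: three measured compounds and one pending

The source may hold more compounds than are shown below. What is called first, only, known or untested is meant among the compounds shown, and "the series" means these compounds.

Of the compounds shown here, three have been measured in an ADME assay on MT4 cells (Homo sapiens) for cytotoxicity, read by MTT assay, with a stated time of 4 days; a higher number here means that more compound is tolerated, a lower number that less compound is tolerated. Compound 1 `COc1cc(C#N)cc(OC)c1Oc1nc(Nc2ccc(C#N)cc2)nc2ccccc12` gives 194000 nM there. Compound 2 `N#Cc1ccc(Nc2nc(Oc3ccc(Cl)cc3)c3ccccc3n2)cc1` gives 198000 nM in this assay, the highest of the three numbers, though its gap to compound 1 lies within the scatter. Compound 3 `CCCOc1cc(C#N)cc(OCC)c1Oc1nc(Nc2ccc(C#N)cc2)nc2ccccc12` gives 123000 nM in this assay, also within the scatter of compound 2. The three numbers sit together. Compound 4 `Cc1ccc(Oc2nc(Nc3ccc(C#N)cc3)nc3ccccc23)cc1` is not yet measured and differs from compound 2 in one place: methyl in place of chloro on an aromatic carbon. Among the compounds with values here, no step between measured compounds shows what this exchange does, so for compound 4 the expected step of a 1.1-fold lower number from compound 2 to compound 4 (0.04 log units; within the scatter) in this assay stays within the scatter, in no firm direction. Compound 4 is estimated at 180000 nM in this assay, with a range of 90000 nM to 350000 nM.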

Compound 4, half-maximal cytotoxic concentration: 87000 nM
Compound 4: the middle estimate sits 2.1-fold (0.32 log units) above what was measured; measured number below the stated range.
By their numbers in this assay, from the lowest: compounds 4, 3, 1 and 2 (each within the scatter of the next, the first and the last beyond it).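

In this assay the change from 4-chlorophenoxy to 4-methylphenoxy gives a 2.3-fold lower number from compound 2 to compound 4 (0.36 log units; beyond the scatter) as the first step read across a single place in the series. The earlier compounds shown here, all within the scatter of one another, gave no sign that one exchange on an aromatic carbon para to a large group could move the number beyond the scatter. No measured evidence bears on what lies behind this step.

From the compounds shown here alone, whether a methoxy or an amine at this place would fall with chloro or with methyl stays open. A single pair also cannot tell whether the same exchange elsewhere in the series gives a step of similar size.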